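Trading a Branched Amine for an Ether on the Core

The source may report more compounds than this note shows. Statements on the series, on what has been measured and on what is new or still open speak of the compounds shown alone.

Compound 2 `COCC(C)(C)Nc1nc(C)nc2c1nnn2-c1ccc(C(C)C)cc1Br` carries a (1-(methoxymethyl)-1-methylethyl)amino group on the shared core. In an in vitro assay on 293-EBNA cells for binding affinity to corticotropin-releasing factor receptor 1 (Homo sapiens) (a lower number here means a stronger inhibitor, a higher number a weaker inhibitor), compound 2 gives 195 nM, the highest of the two single numbers at hand. Its nearest neighbour, compound 1 `CCC(COC)N(C)c1nc(C)nc2c1nnn2-c1ccc(C(C)C)cc1Br`, gives 11.2 nM in this assay, and the step of a 17-fold higher number from compound 1 to compound 2 (1.24 log units; beyond the scatter) is large. Compound 3 `CCC(COC)Nc1nc(C)nc2c1nnn2-c1ccc(C(C)C)cc1Br` gives 7.5 nM; 6.1 nM; 9.4 nM (3 entries) in this assay; the repeated entries the several entries of compound 3 in this assay, 7.5 nM; 6.1 nM; 9.4 nM (3 entries) all sit well below the number for compound 2.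

Compound 4 `CCC(CC)Oc1nc(C)nc2c1nnn2-c1ccc(C(C)C)cc1Br` is the compound still to be measured. Relative to compound 2, the change is (pentan-3-yl)oxy in place of (1-(methoxymethyl)-1-methylethyl)amino on an aromatic carbon. Within the data shown here, no measured step covers this exact exchange. Among the measured compounds shown here, the only step that touches compound 2, from compound 1 to compound 2, shows that altering the side chain can shift the number a great deal, and compounds 1 and 3, with their other side chains, both sit far lower. Compound 4 is therefore expected to land below compound 2, with a step of about a 9.8-fold lower number from compound 2 to compound 4 (0.99 log units; beyond the scatter). Compound 4 is estimated at 20 nM, within a range from 5 nM to 80 nM.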

Compound 4, inhibition constant: 1.9 nM
Compound 4: the middle estimate sits 11-fold (1.02 log units) above what was measured, outside the stated range (below it).
By their numbers in this assay, from the lowest: compound 4; then compound 1; then compound 2.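

At this position on the shared core, a side chain joined through oxygen can replace one joined through nitrogen, and in this assay the (pentan-3-yl)oxy group gives a 100-fold lower number from compound 2 to compound 4 (2.01 log units; beyond the scatter) for the exchange that removes the (1-(methoxymethyl)-1-methylethyl)amino group. The number also falls against the other nitrogen-linked side chain, with a 5.9-fold lower number from compound 1 to compound 4 (0.77 log units; beyond the scatter), so among these compounds a nitrogen link is not needed for a low number here. No measurement shown explains either drop.

Compound 4 differs from compound 2 in both the linking atom and the chain, and the two changes cannot be told apart here. A pentan-3-ylamino group would test the linking atom alone, while a cyclopentyloxy group or a longer chain such as heptan-4-yloxy would test how much the chain on the oxygen can vary.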